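A few compounds are considered here, and "the series" means these few. Any claim that something is new, unique, unknown or untested is made for them only; others in the source may bear on it.

Measured so far in an ADME assay on PBMC cells (Homo sapiens) for cytotoxicity; on this read-out higher numbers stand for lower toxicity in this test and lower numbers for higher toxicity in this test:
compound 1 `Cc1ccnc(OC(c2ccc(C(F)(F)F)cc2)C2CCN(C(C)CCNC(=O)c3c(Cl)cncc3Cl)CC2)c1` — 33600 nM
compound 2 `COC(=O)c1cccc(OC(c2ccc(C(F)(F)F)cc2)C2CCN(C(C)CCNC(=O)c3c(Cl)cncc3Cl)CC2)n1` — 14600 nM
compound 3 `CC(CCNC(=O)c1c(Cl)cncc1Cl)N1CCC(C(Oc2cc(Cl)ccn2)c2ccc(C(F)(F)F)cc2)CC1` — 4260 nM

Compound 1 gives the highest of the three numbers; compound 2 sits closest, with a 2.3-fold lower number from compound 1 to compound 2 (0.36 log units; beyond the scatter), and compound 3 furthest, with a 7.9-fold lower number from compound 1 to compound 3 (0.90 log units; beyond the scatter). Between the two lower compounds, a 3.4-fold lower number from compound 2 to compound 3 (0.53 log units; beyond the scatter).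

Compound 4 `CC(CCNC(=O)c1c(Cl)cncc1Cl)N1CCC(C(Oc2cccc(C#N)n2)c2ccc(C(F)(F)F)cc2)CC1` is not yet measured. Relative to compound 1 the change is 6-cyanopyridin-2-yl in place of 4-methylpyridin-2-yl on an oxygen on a saturated carbon.

For the measured compounds named here, two measured steps bear on this. The step from compound 1 to compound 2 changes the same ring at the same place, 6-(methoxycarbonyl)pyridin-2-yl in place of 4-methylpyridin-2-yl on an oxygen on a saturated carbon, and gave a 2.3-fold lower number from compound 1 to compound 2 (0.36 log units; beyond the scatter). The step from compound 1 to compound 3, chloro in place of methyl on an aromatic carbon, gave a 7.9-fold lower number from compound 1 to compound 3 (0.90 log units; beyond the scatter). Every replacement of the 4-methylpyridin-2-yl group measured so far has moved the number lower, by a modest amount beyond the scatter. For compound 4 a lower number than compound 1 is therefore expected, of a size comparable to the step from compound 1 to compound 2, estimated as a 2.8-fold lower number from compound 1 to compound 4 (0.45 log units; beyond the scatter).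

Estimate for compound 4 in this assay: 12000 nM, expected to fall between 5000 nM and 30000 nM.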

Compound 4, half-maximal cytotoxic concentration: 15700 nM
Compound 4: the middle estimate sits 1.3-fold (0.12 log units) below what was measured; the range from low to high includes it.
By their numbers in this assay, from the lowest: compound 3; then compounds 2 and 4 (each within the scatter of the next); then compound 1.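

In this assay, the 6-cyanopyridin-2-yl group gives a 2.1-fold lower number from compound 1 to compound 4 (0.33 log units; beyond the scatter), so all three replacements of 4-methylpyridin-2-yl shown at this place now lower the number, and none of them matches compound 1. Exchanging the ester for the nitrile gives a 1.1-fold higher number from compound 2 to compound 4 (0.03 log units; within the scatter), so methoxycarbonyl and cyano cannot be told apart on this read-out, a first sign that this ring position tolerates quite different groups without a measurable shift. The larger gap lies elsewhere, with a 3.7-fold higher number from compound 3 to compound 4 (0.57 log units; beyond the scatter), which places the 4-chloropyridin-2-yl group of compound 3 apart from the 6-cyanopyridin-2-yl group of compound 4, though the two differ in both the group and its place on the ring, and nothing measured here accounts for that gap.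

A 6-chloropyridin-2-yl or 4-cyanopyridin-2-yl group would separate the identity of the group from its place on the ring, which the compounds shown leave confounded. Also open, as far as these compounds go, is whether a carboxylic acid or an amine on the same ring would stay level with compound 2 and compound 4 or move away from them.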